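Shortening the bromoalkoxy chain: what compound 4 may show

The source may report more compounds than this note shows. Statements on the series, on what has been measured and on what is new or still open speak of the compounds shown alone.

Measured compounds:
- Compound 1 `COc1ccc(-c2coc3cc(OCCCBr)ccc3c2=O)cc1` — in a functional assay on PC-3 cells (Homo sapiens) for inhibition, read by MTT assay, with a stated time of 48 h (a lower number here means a stronger inhibitor, a higher number a weaker inhibitor), compound 1 gives 62600 nM
- Compound 2 `COc1ccc(-c2coc3cc(OCCCCCBr)ccc3c2=O)cc1` — in this assay compound 2 gives 44800 nM
- Compound 3 `COc1ccc(-c2coc3cc(OCCCCBr)ccc3c2=O)cc1` — in this assay compound 3 gives 55600 nM

The three measured compounds share one core and differ only in the length of the bromoalkoxy chain. From compound 2 to compound 1 the change is bromo in place of 2-bromoethyl on a saturated chain carbon, three bonds along the chain from an oxygen on an aromatic ring; in this assay this gave a 1.4-fold higher number from compound 2 to compound 1 (0.15 log units; within the scatter). The cores of compound 2 and compound 3 differ by bromo in place of bromomethyl on a saturated chain carbon, four bonds along the chain from an oxygen on an aromatic ring, and in this assay this gave a 1.2-fold higher number from compound 2 to compound 3 (0.09 log units; within the scatter). From compound 1 to compound 3 the chain grows by one carbon, and this assay gave a 1.1-fold lower number from compound 1 to compound 3 (0.05 log units; within the scatter). None of these steps leaves the scatter, so the three values do not separate from one another.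

Compound 4 `COc1ccc(-c2coc3cc(OCCBr)ccc3c2=O)cc1` has not been measured. From compound 3 to compound 4 the change is bromo in place of 2-bromoethyl on a saturated chain carbon, two bonds along the chain from an oxygen on an aromatic ring. This is the same kind of change as from compound 2 to compound 1, but the place differs: there it sits three bonds along the chain from an oxygen on an aromatic ring, here two bonds along the chain. Because the earlier step of a 1.4-fold higher number from compound 2 to compound 1 (0.15 log units; within the scatter) stayed within the scatter, the step from compound 3 to compound 4 is expected to be a 1.2-fold higher number from compound 3 to compound 4 (0.09 log units; within the scatter). Compound 4 is thus estimated at 68000 nM in this assay, with a range from 35000 nM to 140000 nM.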

Compound 4, half-maximal inhibitory concentration: 41900 nM
The estimate for compound 4 lay 1.6-fold (0.21 log units) above the measured number; measured number inside the range.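

In this assay all three new steps stay within the scatter: a 1.3-fold lower number from compound 3 to compound 4 (0.12 log units; within the scatter), a 1.1-fold lower number from compound 2 to compound 4 (0.03 log units; within the scatter) and a 1.5-fold lower number from compound 1 to compound 4 (0.17 log units; within the scatter). Replacing 2-bromoethyl with bromo therefore gave no step beyond the scatter on either core, and although the two steps are printed with opposite directions, the gap between them does not leave the scatter of two such steps: the same change on two cores in this assay, a 1.4-fold higher number (0.15 log units; within the scatter) from compound 2 to compound 1 and a 1.3-fold lower number (0.12 log units; within the scatter) from compound 3 to compound 4, 1.9-fold (0.27 log units) apart, within the scatter of two such steps. The other change that appears on two cores behaves in the same way, so the series is compatible with these chain changes carrying over from one core to another, but it does not show that they carry over with a fixed size or direction, since every step is too small to be told from the scatter: the same change on two cores in this assay, a 1.2-fold higher number (0.09 log units; within the scatter) from compound 2 to compound 3 and a 1.5-fold lower number (0.17 log units; within the scatter) from compound 1 to compound 4, 1.9-fold (0.27 log units) apart, within the scatter of two such steps.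

The compounds shown all share one core and differ only in a bromoalkyl chain, so they leave open what an amine or a carboxylic acid in place of the bromo, or a longer chain than that of compound 2, would do. On these data alone, whether any such group would give a step beyond the scatter in this assay also remains open.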